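Aryl hydrazone variation on the shared core: working notes

The source may report more compounds than this note shows. Statements on the series, on what has been measured and on what is new or still open speak of the compounds shown alone.

Measured so far:
Compound 1 `CN(C)CCn1cnnc1-c1cc(Oc2ccc(NC(=O)N/N=C/c3ccc(Cl)cc3Cl)cc2F)ccn1` — 130 nM
Compound 2 `CN(C)CCn1cnnc1-c1cc(Oc2ccc(NC(=O)N/N=C/c3ccc(O)c(F)c3)cc2F)ccn1` — 2620 nM

In a functional assay on NCI-H460 cells (Homo sapiens) for cytotoxicity, read by MTT assay, with a stated time of 72 h (a lower number here means a stronger inhibitor, a higher number a weaker inhibitor), compound 2 gives the highest of the two numbers; its nearest neighbour is compound 1, and the step between them is a 20-fold higher number from compound 1 to compound 2 (1.30 log units; beyond the scatter). Compound 3 `CN(C)CCn1cnnc1-c1cc(Oc2ccc(NC(=O)N/N=C/c3ccc(F)cc3Cl)cc2F)ccn1` is not yet measured. It differs from compound 2 in one place: 2-chloro-4-fluorophenyl in place of 3-fluoro-4-hydroxyphenyl on a carbon with a double bond to nitrogen. Going by the values given here, the only measured step that bears on this change is a 20-fold higher number from compound 1 to compound 2 (1.30 log units; beyond the scatter), which replaced a dichlorinated ring with the 3-fluoro-4-hydroxyphenyl ring and was large. Compound 3 returns to a ring with two halogens and no hydrogen-bond donor or acceptor, so the step is expected to run the other way, as a 10-fold lower number from compound 2 to compound 3 (1.02 log units; beyond the scatter), though not necessarily the full distance back to compound 1, whose value of 130 nM is the anchor. Compound 3 is therefore expected to give about 250 nM in this assay, in the range 80 nM to 800 nM.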

Compound 3, half-maximal inhibitory concentration: 720 nM
Estimate against measurement, compound 3: 2.9-fold (0.46 log units) below, and the stated range covers the measured number.
By their numbers in this assay, from the lowest: compound 1; then compound 3; then compound 2.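

In this assay, 2-chloro-4-fluorophenyl in place of 3-fluoro-4-hydroxyphenyl gives a 3.6-fold lower number from compound 2 to compound 3 (0.56 log units; beyond the scatter) and so recovers only part of the earlier 20-fold higher number from compound 1 to compound 2 (1.30 log units; beyond the scatter) at this position. Two halogens on the ring are therefore not enough to restore the number of compound 1: fluoro in place of chloro on an aromatic carbon alone gives a 5.5-fold higher number from compound 1 to compound 3 (0.74 log units; beyond the scatter) and shows that this position responds to the identity of a single halogen. Nothing available explains these differences.

The compounds shown do not separate the contribution of the hydroxy group in compound 2 from that of its fluoro group. Also open, from the compounds shown here alone, is how bromo or trifluoromethyl in place of the fluoro of compound 3 would compare with the chloro of compound 1.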